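Bromo to chloro on the fused ring of compound 2

The source may hold more compounds than are shown below. What is called first, only, known or untested is meant among the compounds shown, and "the series" means these compounds.

Of the compounds shown here, two of a shared core have been measured in a functional assay on cells (Cancer cell lines, Homo sapiens) for cytotoxicity, read by sulforhodamine B assay, with a stated time of 48 h; a higher number here means a weaker inhibitor of growth, a lower number a stronger inhibitor of growth. Compound 1 `COc1ccc(C2=NN(C3=NC(=O)/C(=C4\C(=O)Nc5ccc(Cl)cc54)S3)C(c3ccc(OC)cc3)C2)cc1` gives 200 nM. Compound 2 `COc1ccc(C2=NN(C3=NC(=O)/C(=C4\C(=O)Nc5ccc(Br)cc54)S3)C(c3ccc(Cl)cc3)C2)cc1` gives 120 nM. The gap between these two numbers is within the usual scatter, so the data show no separation between compound 1 and compound 2 in this assay; compound 2 simply stands beside compound 1 on the numbers at hand.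

Compound 3 `COc1ccc(C2=NN(C3=NC(=O)/C(=C4\C(=O)Nc5ccc(Cl)cc54)S3)C(c3ccc(Cl)cc3)C2)cc1` is the next compound. It differs from compound 2 in one place: chloro in place of bromo on an aromatic carbon. For the measured compounds named here, no measured pair in this set carries exactly this change, so its size is unknown from the data.

Because compound 2 gives 120 nM and the exchange is a halogen for a halogen on the same aromatic carbon, the step is expected to be small, in no clear direction, and not beyond the scatter. The expected step is a 1.3-fold higher number from compound 2 to compound 3 (0.10 log units; within the scatter). Compound 3 is estimated to give 150 nM in this assay, with a range from 75 nM to 300 nM.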

Compound 3, concentration for 50% growth inhibition: 200 nM
Compound 3: the middle estimate sits 1.3-fold (0.12 log units) below what was measured, and the stated range covers the measured number.
By their numbers in this assay, from the lowest: compounds 2, 1 and 3 (each within the scatter of the next).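

In this assay, for the compounds shown here, chloro in place of bromo on an aromatic carbon of a six-membered aromatic ring of carbon only, part of a fused or bridged system of two rings, gives a 1.7-fold higher number from compound 2 to compound 3 (0.22 log units; within the scatter) and is the first direct reading of a change at this position; on this single pair, the data do not separate the two halogens there. The same compound also supplies a second one-place comparison, with methoxy exchanged for chloro at a different aromatic carbon, which gives no change at the digits printed from compound 1 to compound 3 (within the scatter) and likewise does not separate those two groups at that other site. No measurement offered here explains either result.

On these data alone, whether an amine or a carboxylic acid on the aromatic carbon that carries the halogen would give a step beyond the scatter remains open. With both steps within the scatter, the compounds shown also leave open whether any group at either site can move the number in this assay at all, and whether a change at one site would read the same with a different group at the other.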